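Sulfanyl substituent series on a shared core: compound 4

A few compounds are considered here, and "the series" means these few. Any claim that something is new, unique, unknown or untested is made for them only; others in the source may bear on it.

Compound 3 `Cc1cc(Nc2cc(-c3ccccc3)[nH]n2)n2nc(SCc3ccc(Cl)cc3)nc2n1` gives 8260 nM in a functional assay on MCF7 cells (Homo sapiens) for inhibition, read by MTT assay, with a stated time of 72 h (on this read-out higher numbers stand for weaker inhibition and lower numbers for stronger inhibition), the highest of the two numbers shown. Compound 2 `Cc1cc(Nc2cc(-c3ccccc3)[nH]n2)n2nc(SCc3ccccc3Br)nc2n1` gives 3020 nM in this assay, and the step of a 2.7-fold higher number from compound 2 to compound 3 (0.44 log units; beyond the scatter) lies beyond the scatter. Compound 1 `Cc1cc(Nc2cc(-c3ccccc3)[nH]n2)n2nc(SCC3CCCCC3)nc2n1` reports only a limit in this assay, > 50000 nM (the limit of > 50000 nM in this assay, at which 1 of the 3 values shown sits). Compound 4 `CCCSc1nc2nc(C)cc(Nc3cc(-c4ccccc4)[nH]n3)n2n1` is not yet measured; it differs from compound 3 in that (ethyl in place of 4-chlorophenyl on a saturated chain carbon bound to a sulfur). For the measured compounds named here, the steps that bear on this are an at least 6.0-fold lower number from compound 1 to compound 3 (0.78 log units; beyond the scatter) and an at least 16-fold lower number from compound 1 to compound 2 (1.21 log units; beyond the scatter), both putting an aromatic group in place of cyclohexyl on the saturated chain carbon bound to the sulfur; the move back to a plain alkyl group is therefore expected to raise the number. The estimate for compound 4 is 30000 nM, between 8000 nM and 100000 nM, expected as a 3.6-fold higher number from compound 3 to compound 4 (0.56 log units; beyond the scatter), with a real chance that only a limit is reported.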

Compound 4, half-maximal inhibitory concentration: > 50000 nM
Compound 4: only a limit was reported; the forecaster's own chance of this, stated with the estimate: 40%; at least 1.6-fold (0.22 log units) between middle value and limit.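

In this assay, the change away from an aromatic group is costly from either aromatic compound: an at least 6.0-fold higher number from compound 3 to compound 4 (0.78 log units; beyond the scatter), and an at least 16-fold higher number from compound 2 to compound 4 (1.21 log units; beyond the scatter). Among these four compounds, a readable value therefore appears only with the 4-chlorophenyl and 2-bromophenyl groups, and not with ethyl or cyclohexyl on the saturated chain carbon bound to a sulfur. The step between compound 1 and compound 4 cannot be read, as both values are limits: the limit of > 50000 nM in this assay, at which 2 of the 4 values shown sit.

On these data alone, whether an unsubstituted phenyl gives a readable value remains open. So does the outcome with an amine or a carboxylic acid on the chain.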